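The source may hold more compounds than are shown below. What is called first, only, known or untested is meant among the compounds shown, and "the series" means these compounds.

In a functional assay on MDA-MB-231 cells (Homo sapiens) for antiproliferative activity, read by MTT assay, with a stated time of 24 h (on this read-out lower numbers stand for stronger inhibition and higher numbers for weaker inhibition), compound 1 `O=C(O)CC(NS(=O)(=O)c1ccccc1)c1ccccc1` gives > 100000 nM, which is a limit and not a number. Compound 2 `O=C(O)CC(NS(=O)(=O)c1cccc([N+](=O)[O-])c1)c1ccccc1` gives > 100000 nM, also a limit, so its place on the scale is known only as the limit of > 100000 nM in this assay, at which 2 of the 2 values shown sit. Compound 3 `O=C(O)CC(NS(=O)(=O)c1cccc([N+](=O)[O-])c1)c1ccc(Cl)cc1Cl` differs from compound 2 in one place: 2,4-dichlorophenyl in place of phenyl on a saturated chain carbon bound to a saturated chain carbon and a sulfonamide nitrogen. Going by the values given here, the only measured step, a step that the two limits leave unreadable from compound 1 to compound 2, involves a different change and has no readable size. Among the compounds with values here, with a step that the two limits leave unreadable from compound 1 to compound 2 as the only guide, just a modest move toward stronger inhibition is expected in this assay. The expected step runs an at least 1.4-fold lower number from compound 2 to compound 3 (0.15 log units; that floor lies within the scatter). For compound 3 the estimated value is 70000 nM, within an expected range of 15000 nM to 200000 nM.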

Compound 3, half-maximal inhibitory concentration: 77800 nM
Estimate against measurement, compound 3: 1.1-fold (0.05 log units) below; the range from low to high includes it.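

Putting 2,4-dichlorophenyl in place of phenyl on this chain carbon gives the first actual number among these compounds, with an at least 1.2-fold lower number from compound 2 to compound 3 (0.10 log units; that floor lies within the scatter). That floor does not show a change larger than the scatter, and the step from compound 1 to compound 2 cannot be read. Because compound 2 is held at a limit, the true size of the new step stays unknown: the limit of > 100000 nM in this assay, at which 2 of the 3 values shown sit.

On these data alone, it remains open whether a single chlorine would give a similar value. Also open, as far as these compounds go, is how a methoxy group on this ring, or an amide in place of the carboxylic acid, would compare.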